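A few compounds are considered here, and "the series" means these few. Any claim that something is new, unique, unknown or untested is made for them only; others in the source may bear on it.

Compound 1 `CCCCc1cc2ccccc2nc1-c1cc(-c2ccccc2)no1` gives > 100000 nM, a limit.
Compound 2 `CCc1cc2ccccc2nc1-c1cc(-c2ccc(F)cc2)no1` gives > 100000 nM, a limit.
Compound 3 `CCCc1cc2ccccc2nc1-c1cc(-c2ccc(F)cc2)no1` gives 42200 nM.

In a functional assay on PC-3 cells (Homo sapiens) for inhibition, read by MTT assay, with a stated time of 24 h (on this read-out higher numbers stand for weaker inhibition and lower numbers for stronger inhibition), compound 1 gives > 100000 nM, which is a limit of the assay and not a number. Compound 2 likewise gives > 100000 nM, again a limit. Among the measured compounds shown here, compound 3 gives 42200 nM, the only actual number among the three; the other two values sit at the limit of > 100000 nM in this assay, at which 2 of the 3 values shown sit, so compound 3 is the one compound with a measured inhibitory concentration.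

Compound 4 `CCCCc1cc2ccccc2nc1-c1cc(-c2ccc(F)cc2)no1` differs from compound 3 by methyl in place of hydrogen on a saturated chain carbon, three bonds along the chain from an aromatic carbon. For the measured compounds named here, one measured step bears on this change: an at least 2.3-fold lower number from compound 2 to compound 3 (0.37 log units; beyond the scatter), the same kind of chain extension, one bond closer to the aromatic carbon. That step moved a limit to a number, so it is at least modest in size but of unknown true extent. Compound 1 carries the same chain as compound 4 but differs in a further place, and gives only a limit, which neither supports nor contradicts a continued gain.

Compound 4 is therefore expected to give a number near that of compound 3, with a 1.4-fold lower number from compound 3 to compound 4 (0.15 log units; within the scatter) as the estimated step, leaning toward slightly stronger inhibition. The estimate for compound 4 in this assay is 30000 nM, within a range from 8000 nM to 100000 nM.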

Compound 4, half-maximal inhibitory concentration: 26300 nM
The estimate for compound 4 lay 1.1-fold (0.06 log units) above the measured number; measured number inside the range.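

In this assay, taking the chain from propyl to butyl gives a 1.6-fold lower number from compound 3 to compound 4 (0.21 log units; within the scatter), so this further methyl does not separate the two compounds, and the gain seen one bond closer to the aromatic carbon is not shown to continue at this position. Over the longer change from the ethyl chain to the butyl chain, the series gives an at least 3.8-fold lower number from compound 2 to compound 4 (0.58 log units; beyond the scatter), so the chain length does matter across the set even though its last step cannot be resolved, and the fluoro group can now be read on its own for the first time, at an at least 3.8-fold lower number from compound 1 to compound 4 (0.58 log units; beyond the scatter). Both of these larger steps stay open at one end because each starts from a compound that gives no number: the limit of > 100000 nM in this assay, at which 2 of the 4 values shown sit.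

The compounds shown leave open whether a chain longer than butyl would bring a step beyond the scatter or would leave the read-out where it stands. They also do not tell what an amine or a carboxylic acid in place of the butyl chain would do, or how a chloro group would compare with the fluoro group.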